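The source may report more compounds than this note shows. Statements on the series, on what has been measured and on what is new or still open speak of the compounds shown alone.

Measured compounds in a functional assay on HT-29 cells (Homo sapiens) for cytotoxicity, read by MTT assay, with a stated time of 72 h; on this read-out higher numbers stand for weaker inhibition and lower numbers for stronger inhibition:
compound 1 `CN(C)CCn1cnnc1-c1cc(Oc2ccc(NC(=O)N/N=C/c3ccc(Cl)cc3Cl)cc2F)ccn1` gives 390 nM;
compound 2 `CN(C)CCn1cnnc1-c1cc(Oc2ccc(NC(=O)N/N=C/c3ccc(F)cc3)cc2F)ccn1` gives 1370 nM;
compound 3 `CN(C)CCn1cnnc1-c1cc(Oc2ccc(NC(=O)N/N=C/c3ccc(O)c(O)c3)cc2F)ccn1` gives 1890 nM.

Going by the values given here, of these three numbers compound 3 has the highest, and the step of a 4.8-fold higher number from compound 1 to compound 3 (0.69 log units; beyond the scatter) is the only one ending at compound 3 that lies beyond the scatter, while the step of a 1.4-fold higher number from compound 2 to compound 3 (0.14 log units; within the scatter) lies within it. Compound 4 `CN(C)CCn1cnnc1-c1cc(Oc2ccc(NC(=O)N/N=C/c3ccc(O)cc3)cc2F)ccn1` differs from compound 3 by hydrogen in place of hydroxy on an aromatic carbon. Among the compounds with values here, no measured step removes a single hydroxy, so none bears directly on this change. Within the data shown here, the steps of a 3.5-fold higher number from compound 1 to compound 2 (0.55 log units; beyond the scatter) and a 4.8-fold higher number from compound 1 to compound 3 (0.69 log units; beyond the scatter) show only that a ring other than 2,4-dichlorophenyl gives higher numbers, and the step of a 1.4-fold higher number from compound 2 to compound 3 (0.14 log units; within the scatter) shows two such rings giving numbers within the scatter of each other. The step of a 1.3-fold lower number from compound 3 to compound 4 (0.10 log units; within the scatter) is therefore expected to stay within the scatter. Compound 4 is estimated at 1500 nM, with a range from 600 nM to 4000 nM.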

Compound 4, half-maximal inhibitory concentration: 1920 nM
Compound 4: the middle estimate sits 1.3-fold (0.11 log units) below what was measured; the range from low to high includes it.
By their numbers in this assay, from the lowest: compound 1; then compounds 2, 3 and 4 (each within the scatter of the next).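

In this assay, hydrogen in place of one hydroxy on the ring leaves the number within the scatter (a 1.0-fold higher number from compound 3 to compound 4 (0.01 log units; within the scatter)), so this hydroxy shows no measurable effect on the result here. The single hydroxy of the 4-hydroxyphenyl ring and the fluoro of compound 2 also cannot be told apart (a 1.4-fold higher number from compound 2 to compound 4 (0.15 log units; within the scatter)), while the 2,4-dichlorophenyl ring stays clearly apart from this ring (a 4.9-fold higher number from compound 1 to compound 4 (0.69 log units; beyond the scatter)). No measurement shown explains these numbers. Still open, from the compounds shown here alone, is whether a single chlorine, a methoxy or an amine on this ring would give a number like that of compound 1 or like those of the other three.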